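The compounds below may be only part of what the source reports. "The series", "measured", "known", "first", "only" and "open" are said of these compounds alone.

Going by the values given here, in an ADME assay on L02 cells (Homo sapiens) for inhibition, read by CCK-8 assay, with a stated time of 48 h (a lower number here means a stronger inhibitor of growth, a higher number a weaker inhibitor of growth), compound 3 `CCN1CCN(c2ccc(Nc3ncc(Cl)c(Nc4ccccc4C)n3)cc2)CC1` gives 970 nM, the lowest of the two numbers measured so far. Compound 2 `Cc1ccccc1Nc1nc(Nc2ccc(N3CCN(C)CC3)cc2)ncc1Cl` gives 6510 nM. Compound 1 `Cc1ccccc1Nc1nc(Nc2ccccc2)ncc1Cl` does not give a number at all: its result is a limit of the assay, > 100000 nM, which is the limit of > 100000 nM in this assay, at which 1 of the 3 values shown sits. Compound 4 `Cc1ccccc1Nc1nc(Nc2ccc(N3CCCCC3)cc2)ncc1Cl` differs from compound 3 in one place: piperidin-1-yl in place of 4-ethylpiperazin-1-yl on an aromatic carbon. The measured steps that bear on this are an at least 100-fold lower number from compound 1 to compound 3 (2.01 log units; beyond the scatter), an at least 15-fold lower number from compound 1 to compound 2 (1.18 log units; beyond the scatter) and a 6.7-fold lower number from compound 2 to compound 3 (0.83 log units; beyond the scatter), all showing that the group at this position shifts the number strongly. Among the compounds with values here, this particular swap has no direct precedent among the measured steps, so its direction is uncertain; a modest move toward a higher number is expected, a 5.2-fold higher number from compound 3 to compound 4 (0.71 log units; beyond the scatter). Compound 4 is therefore estimated at 5000 nM, with a range from 1200 nM to 25000 nM.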

Compound 4, concentration for 50% growth inhibition: 5690 nM
Beside the measured number, compound 4's estimate is 1.1-fold (0.06 log units) below it; measured number inside the range.
By their numbers in this assay, from the lowest: compound 3; then compounds 4 and 2 (each within the scatter of the next). At a limit, above all of these: compound 1.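

In this assay, a ring with no second nitrogen still counts: piperidin-1-yl gives an at least 17-fold lower number from compound 1 to compound 4 (1.24 log units; beyond the scatter), though compound 1 stands at a limit, so this step is only a bound: the limit of > 100000 nM in this assay, at which 1 of the 4 values shown sits. The ring nitrogen alone does not set the number, since a 1.1-fold lower number from compound 2 to compound 4 (0.06 log units; within the scatter), which leaves 4-methylpiperazin-1-yl and piperidin-1-yl indistinguishable here. Only 4-ethylpiperazin-1-yl stands apart, with a 5.9-fold higher number from compound 3 to compound 4 (0.77 log units; beyond the scatter), so the ethyl group on the ring nitrogen, not the nitrogen itself, marks the difference among these three compounds. From the compounds shown here alone, whether a longer chain on that nitrogen, such as propyl, would lower the number further remains open. So does the result of morpholin-4-yl, which has oxygen in the ring.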